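Thiazolyl for trifluoromethyl on the aminopyridine arm

The source may hold more compounds than are shown below. What is called first, only, known or untested is meant among the compounds shown, and "the series" means these compounds.

Compound 1 `O=C1O[C@]2(CC[C@H](CNc3ccc(-c4ncccn4)cn3)CC2)CN1c1ccccn1`: 0.159 nM
Compound 2 `Cc1ccccc1-c1ccc(NC[C@H]2CC[C@]3(CC2)CN(c2cccnn2)C(=O)O3)nn1`: 0.0631 nM
Compound 3 `O=C1O[C@]2(CC[C@H](CNc3ccc(C(F)(F)F)cn3)CC2)CN1c1ccccn1`: 1 nM

Of the compounds shown here, three sharing a spirocyclic core have been measured in a functional assay for antagonist activity at Neuropeptide Y receptor type 5 (Homo sapiens); on this read-out lower numbers stand for stronger inhibition and higher numbers for weaker inhibition. Compound 1 gives 0.159 nM, compound 2 gives 0.0631 nM, and compound 3 gives 1 nM. Compound 3 therefore sits at the top of the range: its number lies beyond the scatter above that of compound 1 and further still above that of compound 2, so it is the weakest of the three.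

Compound 4 `O=C1O[C@]2(CC[C@H](CNc3ccc(-c4nccs4)cn3)CC2)CN1c1ccccn1` differs from compound 3 by 1,3-thiazol-2-yl in place of trifluoromethyl on an aromatic carbon. Among the measured compounds shown here, the one measured step that bears on this change is a 6.3-fold higher number from compound 1 to compound 3 (0.80 log units; beyond the scatter), where a six-membered aromatic ring gave way to trifluoromethyl and the number rose. Compound 4 reverses that kind of move, putting a small aromatic ring back in the same place, though a five-membered one rather than the pyrimidin-2-yl of compound 1. The expectation for compound 4 is accordingly a step downward, of a size comparable to that earlier step, shown as a 4.0-fold lower number from compound 3 to compound 4 (0.60 log units; beyond the scatter). Compound 4 is estimated at 0.25 nM in this assay, with a range from 0.08 nM to 0.8 nM.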

Compound 4, inhibition constant: 0.126 nM
Compound 4: the middle estimate sits 2.0-fold (0.30 log units) above what was measured, and the stated range covers the measured number.
By their numbers in this assay, from the lowest: compounds 2, 4 and 1 (each within the scatter of the next, the first and the last beyond it); then compound 3.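

In this assay, the change shows a 7.9-fold lower number from compound 3 to compound 4 (0.90 log units; beyond the scatter), so at this place, on an aromatic carbon para to a large group, the gain over trifluoromethyl is not tied to pyrimidin-2-yl: a five-membered aromatic ring carrying sulfur and nitrogen also gives it. The comparison with the six-membered ring shows a 1.3-fold lower number from compound 1 to compound 4 (0.10 log units; within the scatter), so this read-out does not separate 1,3-thiazol-2-yl from pyrimidin-2-yl, and the two aromatic rings stand together apart from trifluoromethyl in the compounds shown. Nothing available explains why either ring gives a lower number than trifluoromethyl at this place.

The compounds shown hold only these three groups at this place, so it remains open whether a plain phenyl ring, a morpholine or a carboxylic acid would keep the number as low as the two heteroaromatic rings do. Among the compounds shown here, it is also open whether 1,3-thiazol-2-yl would give a similar number alongside the other groups of compound 2, since each comparison here rests on the single core shared by compound 1, compound 3 and compound 4.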